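Sulfonamide series: swapping the aryl on the sulfonamide nitrogen

This account rests on a few compounds, and the source may have more. Where it says the series, first, only, none or still open, it means among the compounds named here.

Compound 1 `CCCCCc1ccc(NS(=O)(=O)c2ccc(N3CCNC3=O)cc2)cc1` gives only an assay limit, > 1000 nM.
Compound 2 `COc1ccccc1NS(=O)(=O)c1ccc(N2CCNC2=O)cc1` gives 770 nM.
Compound 3 `CC(C)(C)c1ccc(NS(=O)(=O)c2ccc(N3CCNC3=O)cc2)cc1` gives only an assay limit, > 1000 nM.

Going by the values given here, in a functional assay on MCF7 cells (Homo sapiens) for antiproliferative activity, read by sulforhodamine B assay, with a stated time of 48 h (a lower number here means a stronger inhibitor, a higher number a weaker inhibitor), compound 2 is the one compound with a real number; the other two sit at a limit (the limit of > 1000 nM in this assay, at which 2 of the 3 values shown sit). The unmeasured compound 4 `Cc1cccc(NS(=O)(=O)c2ccc(N3CCNC3=O)cc2)c1` differs from compound 2 by 3-methylphenyl in place of 2-methoxyphenyl on a sulfonamide nitrogen. Among the compounds with values here, no measured step touches this position: the only measured step, a step that the two limits leave unreadable from compound 1 to compound 3, changes a different group and its size cannot be read. So the expectation rests on compound 2 alone, with the knowledge that two close relatives were too weak to measure. Compound 4 is expected at about 1000 nM, between 400 nM and 3000 nM, meaning an expected step of a 1.3-fold higher number from compound 2 to compound 4 (0.11 log units; within the scatter).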

Compound 4, half-maximal inhibitory concentration: 190 nM
For compound 4 the middle estimate is 5.3-fold (0.72 log units) above the measured one; the measured number lies below the stated range.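

In this assay, going by these compounds alone, this swap on the sulfonamide nitrogen gives a 4.1-fold lower number from compound 2 to compound 4 (0.61 log units; beyond the scatter), the first readable evidence that the aryl group at this position can shift antiproliferative potency. Compound 4 differs from compound 2 in both the substituent and its numbered ring position, so these compounds cannot separate the two changes. The only other step, which cannot be read, offers no comparison, as both of its compounds carry a limit rather than a number: the limit of > 1000 nM in this assay, at which 2 of the 4 values shown sit.

Still open, going by these compounds, is whether one substituent change alone would produce a similar step. It is also unknown how an amine or a carboxylic acid on this aryl ring would behave.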